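The source may hold more compounds than are shown below. What is called first, only, known or untested is meant among the compounds shown, and "the series" means these compounds.

Working notes on the series. Among the compounds with values here, compound 2 `CCCCCCCCC(=O)N1c2ccccc2CCC1C(=O)Nc1cc(C(F)(F)F)cc(C(F)(F)F)c1` is the one member that gives a number in a functional assay on HCT-15 cells (Homo sapiens) for cytotoxicity, read by sulforhodamine B assay, with a stated time of 72 h; a lower number here means a stronger inhibitor of growth, a higher number a weaker inhibitor of growth: compound 2 gives 4970 nM. Compound 1 `CC(=O)N1c2ccccc2CCC1C(=O)Nc1cc(C(F)(F)F)cc(C(F)(F)F)c1` reaches only a limit, > 70000 nM, in this assay. Compound 3 `CC(=O)N1c2ccccc2CCC1C(=O)Nc1ccccc1C(F)(F)F` likewise sits at a limit, > 80000 nM, in this assay. Within the data shown here, the single measured step, an at least 14-fold lower number from compound 1 to compound 2 (1.14 log units; beyond the scatter), is the only guide to what the group on the carbonyl carbon bound to the ring nitrogen does, and it is large. Compound 4 `O=C(Nc1cc(C(F)(F)F)cc(C(F)(F)F)c1)C1CCc2ccccc2N1C(=O)c1cccc(Cl)c1` changes that same position: 3-chlorophenyl in place of octyl on a carbonyl carbon. The entering group is close in count of heavy atoms to the leaving chain, so the step from compound 1 to compound 2 says little about whether an aromatic ring will serve as the chain did; the data hold no aroyl group for comparison. The number for compound 4 is therefore expected near that of compound 2, with wide uncertainty in both directions, a step of a 1.6-fold higher number from compound 2 to compound 4 (0.21 log units; within the scatter). Compound 4 is estimated at 8000 nM, between 2000 nM and 40000 nM.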

Compound 4, concentration for 50% growth inhibition: 625 nM
The estimate for compound 4 lay 13-fold (1.11 log units) above the measured number; the measured number lies below the stated range.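

With 3-chlorophenyl in place of octyl on the carbonyl carbon bound to the ring nitrogen, the series shows an 8.0-fold lower number from compound 2 to compound 4 (0.90 log units; beyond the scatter), so a long chain is not needed for growth inhibition at this position, and an aromatic ring serves better than octyl. In this assay compound 1 stands at a limit, > 70000 nM, and not at a number. The change from methyl to 3-chlorophenyl therefore reads as an at least 110-fold lower number from compound 1 to compound 4 (2.04 log units; beyond the scatter), a size that rests on that limit.

Nothing measured here gives a cause for this gain. From the compounds shown here alone, whether the chlorine is needed stays open, as does whether an unsubstituted phenyl or a cyclohexyl would serve as well, and whether 3-chlorophenyl would give a similar gain on the core of compound 3.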